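Heteroaryl swap on the sulfur of the urea series

This account rests on a few compounds, and the source may have more. Where it says the series, first, only, none or still open, it means among the compounds named here.

Compound 3 `CCCCCCCN(CCCCCSc1[nH]cnc2ncnc1-2)C(=O)Nc1ccc(F)cc1F` gives the lowest number of the three measured compounds in an assay on cells (Macrophage) for inhibition of sterol O-acyltransferase 1 (Mus musculus) (a higher number here means a weaker inhibitor, a lower number a stronger inhibitor), at 5320 nM. Compound 1 `CCCCCCCN(CCCCCSc1nc(O)c2ccccc2n1)C(=O)Nc1ccc(F)cc1F` in this assay gives 11000 nM, and compound 2 `CCCCCCCN(CCCCCSc1nc(N)c2c[nH]nc2n1)C(=O)Nc1ccc(F)cc1F` gives 72500 nM. The step of a 2.1-fold lower number from compound 1 to compound 3 (0.32 log units; beyond the scatter) was modest and the step of a 14-fold lower number from compound 2 to compound 3 (1.13 log units; beyond the scatter) was large, so exchanging the aromatic group on the sulfur has moved this assay in both directions and by quite different amounts. Compound 4 `CCCCCCCN(CCCCCSc1n[nH]c(-c2ccccc2)n1)C(=O)Nc1ccc(F)cc1F` carries the change (a group of 11 heavy atoms (8 carbon, 3 nitrogen; one five-membered aromatic ring with 3 hetero atoms, one six-membered aromatic ring of carbon only) in place of a group of 9 heavy atoms (5 carbon, 4 nitrogen; one five-membered aromatic ring with 2 hetero atoms, one six-membered aromatic ring with 2 hetero atoms), on a sulfur), bringing in 5-phenyl-1H-1,2,4-triazol-3-yl on the sulfur whose other neighbour is a saturated chain carbon. Among the measured compounds shown here, no measured step covers a group of this kind, so the best guide is that compound 1, which also bears a carbon-only six-membered ring, gives 11000 nM, while every change away from compound 3 so far has raised the number. The expected step is therefore a 1.9-fold higher number from compound 3 to compound 4 (0.27 log units; within the scatter), a moderate weakening. Compound 4 is estimated to give 10000 nM in this assay, within a range from 3000 nM to 35000 nM.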

Compound 4, half-maximal inhibitory concentration: 4180 nM
Estimate against measurement, compound 4: 2.4-fold (0.38 log units) above, within the range that was stated.
By their numbers in this assay, from the lowest: compounds 4 and 3 (each within the scatter of the next); then compound 1; then compound 2.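

With 5-phenyl-1H-1,2,4-triazol-3-yl on the sulfur, the number in this assay stays level with the best of the series (a step of a 1.3-fold lower number from compound 3 to compound 4 (0.10 log units; within the scatter)), so two quite different groups now fit this position equally well. A carbon-only six-membered ring does not in itself set the number, and neither does a group of 11 heavy atoms: both compound 1 and compound 4 carry these, yet they are separated by a real gap (a 2.6-fold lower number from compound 1 to compound 4 (0.42 log units; beyond the scatter)), and the distance to the poorest member is large (a 17-fold lower number from compound 2 to compound 4 (1.24 log units; beyond the scatter)). No measurement offered here explains these differences.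

The compounds shown leave open how much the phenyl ring itself contributes, which a methyl group in its place on the triazole would test. They also leave open whether a fluorine or methoxy group on that phenyl ring would move the number at all.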